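Shifting a Chlorine Around a Phenyl Ring

The compounds below may be only part of what the source reports. "The series", "measured", "known", "first", "only" and "open" are said of these compounds alone.

Measured so far:
- compound 1, `Oc1cccc(-c2cc(-c3cccc(Cl)c3)nc(-c3ccccn3)c2)c1`, a functional assay on HCT-15 cells (Homo sapiens) for cytotoxicity, read by CCK-8 assay and cell counting, with a stated time of 2 days; a lower number here means a stronger inhibitor, a higher number a weaker inhibitor: "not determined" (no result reported)
- compound 2, `Oc1cccc(-c2cc(-c3cccc(Cl)c3)nc(-c3ccco3)c2)c1`, this assay: 2460 nM
- compound 3, `Oc1cccc(-c2cc(-c3cccs3)nc(-c3ccccc3Cl)c2)c1`, this assay: 2790 nM

Compound 3 gives the highest of the two numbers reported in this assay, but the value of compound 2 lies within the usual scatter of it, so the two cannot be told apart, and compound 1 has no number at all. Compound 4, `Oc1cccc(-c2cc(-c3cccc(Cl)c3)nc(-c3cccs3)c2)c1`, has not yet been measured. It differs from compound 3 in a single way: 3-chlorophenyl in place of 2-chlorophenyl on an aromatic carbon. The same atoms are present in both; only the point at which the chlorine sits on its phenyl ring has moved.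

Within the data shown here, no measured pair in this set shows this change on its own, so its size is unknown here. Compound 2 also carries a 3-chlorophenyl group and gives 2460 nM, a number close to that of compound 3. On that basis the step from compound 3 to compound 4 in this assay is expected to be small, a 1.1-fold lower number from compound 3 to compound 4 (0.05 log units; within the scatter), not beyond the scatter in either direction. Compound 4 is therefore estimated at 2500 nM, with a likely range from 1000 nM to 6000 nM.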

Compound 4, half-maximal inhibitory concentration: 2610 nM
Compound 4: middle estimate off by 1.0-fold (0.02 log units), on the low side, and the stated range covers the measured number.
By their numbers in this assay, from the lowest: compounds 2, 4 and 3 (each within the scatter of the next).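

Placing the chlorine as 2-chlorophenyl or as 3-chlorophenyl, on the aromatic carbon next to the ring nitrogen, makes no readable difference in this assay (a 1.1-fold lower number from compound 3 to compound 4 (0.03 log units; within the scatter)), so for this pair the position of the chlorine on its phenyl ring does not register in the cell result. The second new comparison concerns the other aryl group: with the 3-chlorophenyl group held in place, thiophen-2-yl in place of furan-2-yl also stays inside the noise of the assay (a 1.1-fold higher number from compound 2 to compound 4 (0.03 log units; within the scatter)), so these two five-membered rings cannot be told apart here. Nothing measured here explains why either change leaves the number where it is.

The compounds shown vary only the chlorine position and the five-membered ring, so they leave open whether a different kind of group on that phenyl ring, such as an amine or a carboxylic acid, would shift the result beyond the scatter. They also leave open how much the 3-hydroxyphenyl group contributes, since every compound carries it and none has a methoxy group in its place.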